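The compounds below may be only part of what the source reports. "The series", "measured", "known", "first", "only" and "open" are said of these compounds alone.

Measured so far in an in vitro ADME assay on microsomes from liver (Rattus norvegicus) for metabolic stability; on this read-out higher numbers stand for fast clearance and lower numbers for slow clearance:
- compound 3, `O=C(NCC1CCOCC1)c1cnc(Nc2cccc(Br)c2)cc1C1CC1`: 1.6 mL.min-1.g-1
- compound 1, `N#Cc1cccc(Nc2cc(C3CC3)c(C(=O)NCC3CCOCC3)cn2)c1`: "not determined" (no result reported)
- compound 2, `COc1cccc(Nc2cc(C3CC3)c(C(=O)NCC3CCOCC3)cn2)c1`: "not determined" (no result reported)

Going by the values given here, compound 3 is the only member of the series with a number in this assay; compounds 1 and 2 carry no result, so nothing can be said about how the nitrile or the methoxy variant compares with it. On the numbers shown, compound 3 therefore stands alone, and its value in this assay is the sole reference point for the series.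

The next compound, compound 4, `O=C(NCC1CCOCC1)c1cnc(Nc2cccc(OC(F)(F)F)c2)cc1C1CC1`, differs from compound 3 in one place: trifluoromethoxy in place of bromo on an aromatic carbon. Among the compounds with values here, no step between two measured compounds covers this kind of exchange, so there is no precedent to lean on.

Compound 4 is expected to sit close to compound 3 in this assay, with the step of a 1.4-fold higher number from compound 3 to compound 4 (0.14 log units; within the scatter) estimated as at most a small shift toward faster clearance, not clearly beyond the usual scatter. The estimate for compound 4 in this assay is 2.2 mL.min-1.g-1, expected to fall between 0.9 mL.min-1.g-1 and 5.5 mL.min-1.g-1.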

Compound 4, intrinsic clearance in microsomes: 3.5 mL.min-1.g-1
Compound 4: middle estimate off by 1.6-fold (0.20 log units), on the low side; measured number inside the range.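

In this assay, going by these compounds alone, this position on the aromatic ring responds to substitution: trifluoromethoxy in place of bromo gives a 2.2-fold higher number from compound 3 to compound 4 (0.34 log units; beyond the scatter) and provides the first readable step. The exchange brings in more heavy atoms and a hydrogen-bond acceptor, and the number moves toward the fast-clearance end of the read-out, so bromo and trifluoromethoxy are not interchangeable here, although this rests on a single pair. Within the data shown here, nothing measured so far accounts for this step.

Steps involving compounds 1 and 2 cannot be read, so the nitrile and the methoxy remain unplaced relative to bromo and trifluoromethoxy. Going by these compounds, whether an amine or a carboxylic acid on the same aromatic carbon would raise the number further or bring it back toward that of compound 3 remains open.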